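A cyano group added to compound 3

The compounds below may be only part of what the source reports. "The series", "measured", "known", "first", "only" and "open" are said of these compounds alone.

Compound 1 `O=C(O)CC(NS(=O)(=O)c1ccccc1)c1ccccc1` gives > 100000 nM (a limit)
Compound 2 `N#Cc1ccc(S(=O)(=O)NC(CC(=O)O)c2ccccc2)cc1` gives 48700 nM
Compound 3 `O=C(O)CC(NS(=O)(=O)c1ccccc1)c1ccccc1F` gives > 100000 nM (a limit)

All three values come from a functional assay on MDA-MB-231 cells (Homo sapiens) for antiproliferative activity, read by MTT assay, with a stated time of 24 h; on this read-out higher numbers stand for weaker inhibition and lower numbers for stronger inhibition. Compound 3 is known only by a limit and stands at the limit of > 100000 nM in this assay, at which 2 of the 3 values shown sit. Compound 4 `N#Cc1ccc(S(=O)(=O)NC(CC(=O)O)c2ccccc2F)cc1` differs from compound 3 by cyano in place of hydrogen on an aromatic carbon. Within the data shown here, the same change on compound 1 gave an at least 2.0-fold lower number from compound 1 to compound 2 (0.31 log units; beyond the scatter), the one readable guide. The fluoro change gave a step that the two limits leave unreadable from compound 1 to compound 3. A modest step towards a lower number is therefore expected, though compound 3 offers no exact starting point. The expected change is an at least 2.2-fold lower number from compound 3 to compound 4 (0.34 log units; beyond the scatter). Compound 4 is estimated at 45000 nM, with an expected range from 18000 nM to 100000 nM.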

Compound 4, half-maximal inhibitory concentration: 69700 nM
Compound 4: the middle estimate sits 1.5-fold (0.19 log units) below what was measured, within the range that was stated.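

With the fluoro group in place, the cyano change in this assay still gives a measurable value, but the step is only a floor (an at least 1.4-fold lower number from compound 3 to compound 4 (0.15 log units; that floor lies within the scatter)). The fluoro change, unreadable on the core without cyano, can now be read on the core with it (a 1.4-fold higher number from compound 2 to compound 4 (0.16 log units; within the scatter)). Whether the cyano change has the same size on both cores cannot be settled: the same change on two cores in this assay, an at least 2.0-fold lower number (0.31 log units; beyond the scatter) from compound 1 to compound 2 and an at least 1.4-fold lower number (0.15 log units; that floor lies within the scatter) from compound 3 to compound 4; the limit leaves it open whether they differ.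

The compounds shown leave open how an amine or a methoxy group in place of the cyano group would read in this assay.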